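Hydroxyacyl variation on the bicyclic proline amide series

The source may report more compounds than this note shows. Statements on the series, on what has been measured and on what is new or still open speak of the compounds shown alone.

Measured compounds:
compound 1 `CC(C)(C)[C@@H](O)C(=O)N1[C@@H]2C[C@@H]2C[C@H]1C(=O)NCc1cc(Cl)ccc1-n1cnnn1` — 1100 nM
compound 2 `O=C(NCc1cc(Cl)ccc1-n1cnnn1)[C@@H]1C[C@@H]2C[C@@H]2N1C(=O)[C@H](O)c1cccc(Cl)c1` — 1000 nM
compound 3 `O=C(NCc1cc(Cl)ccc1-n1cnnn1)[C@@H]1C[C@@H]2C[C@@H]2N1C(=O)[C@H](O)CC1CC1` — 1700 nM

In a functional assay on a cell-free system (plasma, Homo sapiens), with a stated time of 3 min (a lower number here means a stronger inhibitor, a higher number a weaker inhibitor), compound 3 gives the highest of the three numbers, yet compound 1 sits within the scatter of it and compound 2 likewise, so no order among the three can be drawn.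

Compound 4 `CC(C)(C)[C@@H](O)C(=O)N1[C@H](C(=O)NCc2cc(Cl)ccc2-n2cnnn2)C[C@@H]2C[C@@H]21` is unmeasured. It differs from compound 3 in one place: tert-butyl in place of cyclopropylmethyl on a saturated chain carbon bound to a carbonyl carbon and an oxygen on a saturated carbon.

Among the compounds with values here, only one measured step touches the same place: a 1.7-fold higher number from compound 2 to compound 3 (0.23 log units; within the scatter), a change within the scatter. Compound 1 also bears tert-butyl on a saturated chain carbon bound to a carbonyl carbon and an oxygen on a saturated carbon, and in this assay compound 1 gives 1100 nM, within the scatter of compound 3. Because a 1.7-fold higher number from compound 2 to compound 3 (0.23 log units; within the scatter) was within the scatter and compound 1 gives 1100 nM, a step no larger than the scatter is expected, if anything toward a slightly lower number.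

For compound 4 the estimate in this assay is 1100 nM, with a range from 550 nM to 2300 nM. This estimate means a step of a 1.5-fold lower number from compound 3 to compound 4 (0.19 log units; within the scatter), expected to stay within the scatter.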

Compound 4, half-maximal inhibitory concentration: 1500 nM
The estimate for compound 4 lay 1.4-fold (0.13 log units) below the measured number, within the range that was stated.
By their numbers in this assay, from the lowest: compounds 2, 1, 4 and 3 (each within the scatter of the next).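

Tert-butyl and cyclopropylmethyl on this saturated chain carbon give a 1.1-fold lower number from compound 3 to compound 4 (0.05 log units; within the scatter), and tert-butyl against 3-chlorophenyl gives a 1.5-fold higher number from compound 2 to compound 4 (0.18 log units; within the scatter), so in this assay these three groups cannot be told apart. Configuration is a new kind of change for the series: with two ring stereocentres drawn the other way, the result is a 1.4-fold higher number from compound 1 to compound 4 (0.13 log units; within the scatter), so this change also leaves the number within the scatter. That reading covers this single pair, and its value lies in isolating configuration from any change of group: the fact that compounds 1 and 4 differ only in the configuration as drawn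

Every step shown lies within the scatter, so it remains open whether any group at this carbon can move the number beyond it. An amine, a carboxylic acid or a longer chain on this carbon would put that question to the test.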